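Aryl replacement on the carbon double-bonded to nitrogen

This account rests on a few compounds, and the source may have more. Where it says the series, first, only, none or still open, it means among the compounds named here.

Measured so far:
Compound 1 `Cn1c(=O)c(=O)n(C2CCCC2)c2nc(N/N=C/c3ccc(O)cc3)ncc21`: in a functional assay on PC-3 cells (Homo sapiens) for antiproliferative activity, read by MTT assay (on this read-out higher numbers stand for weaker inhibition and lower numbers for stronger inhibition), compound 1 reaches only the assay limit, > 100000 nM.
Compound 2 `Cc1cccc(/C=N/Nc2ncc3c(n2)n(C2CCCC2)c(=O)c(=O)n3C)c1`: in this assay compound 2 gives 53600 nM.

For the measured compounds named here, compound 2 holds the only numerical value; the other entry is a limit, as the limit of > 100000 nM in this assay, at which 1 of the 2 values shown sits, records. Going by the values given here, the single measured step, an at least 1.8-fold lower number from compound 1 to compound 2 (0.27 log units; that floor lies within the scatter), runs from that limit to the one number and its floor lies within the scatter, so it gives no firm direction.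

Compound 3 `CSc1ccc(/C=N/Nc2ncc3c(n2)n(C2CCCC2)c(=O)c(=O)n3C)cc1` differs from compound 2 as follows: 4-(methylsulfanyl)phenyl in place of 3-methylphenyl on a carbon with a double bond to nitrogen. The 4-(methylsulfanyl)phenyl group brings one hydrogen-bond acceptor where the 3-methylphenyl group had none. Among the compounds with values here, no measured step touches a 4-(methylsulfanyl)phenyl group, and the one step available compares 4-hydroxyphenyl with 3-methylphenyl, so it bears on this change only loosely.

With so little to lean on, compound 3 is expected to stay close to compound 2, a step of a 1.0-fold higher number from compound 2 to compound 3 (0.01 log units; within the scatter), no larger than the scatter, and possibly ending at the assay limit. Compound 3 is therefore estimated at 55000 nM, within 20000 nM to 150000 nM.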

Compound 3, half-maximal inhibitory concentration: 21000 nM
Estimate against measurement, compound 3: 2.6-fold (0.42 log units) above, within the range that was stated.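

The aryl group on the carbon with a double bond to nitrogen now shows a readable effect in this assay: 4-(methylsulfanyl)phenyl in place of 3-methylphenyl gives a 2.6-fold lower number from compound 2 to compound 3 (0.41 log units; beyond the scatter). Methylsulfanyl in place of hydroxy on an aromatic carbon gives an at least 4.7-fold lower number from compound 1 to compound 3 (0.67 log units; beyond the scatter), so this comparison, unlike the earlier one with 3-methylphenyl, clears the scatter even at its floor. Compound 1 stands at a limit and not at a number, so this second step fixes only a minimum size and no exact one, because of the following: the limit of > 100000 nM in this assay, at which 1 of the 3 values shown sits.

The names 3-methylphenyl and 4-(methylsulfanyl)phenyl differ both in the substituent and in the number that places it, so the step to compound 3 cannot say which of the two matters. A 4-methylphenyl group would separate them, and a 4-aminophenyl or 4-(methylsulfonyl)phenyl group would show whether the trend seen so far extends beyond the sulfide of compound 3.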